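Propargyl ether in place of methyl ether on compound 2

A few compounds are considered here, and "the series" means these few. Any claim that something is new, unique, unknown or untested is made for them only; others in the source may bear on it.

Measured so far:
compound 1, `COc1ccc(C(=O)c2cc(OC)c(OC)c(OC)c2)cc1NC(=O)/C=C/c1cc(OC)c(OC)c(OC)c1`, gives 1200 nM
compound 2, `COc1cccc(/C=C/C(=O)Nc2cc(C(=O)c3cc(OC)c(OC)c(OC)c3)ccc2OC)c1`, gives 3100 nM

In a functional assay on B16 cells (Mus musculus) for cytotoxicity, read by MTT assay, with a stated time of 72 h (on this read-out higher numbers stand for weaker inhibition and lower numbers for stronger inhibition), compound 2 holds the highest of the two numbers, and its nearest neighbour is compound 1. Among the measured compounds shown here, the only measured step is a 2.6-fold higher number from compound 1 to compound 2 (0.41 log units; beyond the scatter), which concerns the trimethoxyphenyl on the double-bonded chain carbon and nothing else.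

Compound 3, `C#CCOc1cccc(/C=C/C(=O)Nc2cc(C(=O)c3cc(OC)c(OC)c(OC)c3)ccc2OC)c1`, differs from compound 2 by ethynyl in place of hydrogen on a saturated chain carbon bound to an oxygen on an aromatic ring. For the measured compounds named here, no measured step touches this change: the step from compound 1 to compound 2 alters a different part of the molecule, and no measured pair shows a methyl ether turned into a propargyl ether. The expectation therefore rests on compound 2 alone, with no step beyond the scatter expected in either direction. The expected step is a 1.0-fold lower number from compound 2 to compound 3 (0.01 log units; within the scatter). Compound 3 is estimated at 3000 nM, with a range from 900 nM to 10000 nM.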

Compound 3, half-maximal inhibitory concentration: 12200 nM
Beside the measured number, compound 3's estimate is 4.1-fold (0.61 log units) below it; measured number outside the range, above it.
By their numbers in this assay, from the lowest: compound 1; then compound 2; then compound 3.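

In this assay, the oxygen on the aromatic ring proves not to be a neutral place for growth: turning the methyl ether into a propargyl ether gives a 3.9-fold higher number from compound 2 to compound 3 (0.59 log units; beyond the scatter), so the added ethynyl weakens the compound rather than leaving it unchanged. Among the compounds shown here, replacing 3,4,5-trimethoxyphenyl with 3-(propargyloxy)phenyl gives a 10-fold higher number from compound 1 to compound 3 (1.01 log units; beyond the scatter), the only step so far graded large. Nothing available explains why the ethynyl has this effect.

The compounds shown leave open whether an ethyl group or a longer chain ending in an amine on this oxygen would hold the number of compound 2. They also leave open whether a propargyl ether would cost as much on the 3,4,5-trimethoxyphenyl of compound 1.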